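The source may report more compounds than this note shows. Statements on the series, on what has been measured and on what is new or still open speak of the compounds shown alone.

Measured so far in a functional assay (Homo sapiens) for inhibition; on this read-out lower numbers stand for stronger inhibition and higher numbers for weaker inhibition:

compound 1, `CS(=O)(=O)c1ccc(CSc2nc(-c3ccc(F)cc3)c(-c3ccncc3)[nH]2)cc1`, 330 nM
compound 2, `CSc1ccc(CSc2nc(-c3ccc(Cl)cc3)c(-c3ccncc3)[nH]2)cc1`, 2200 nM
compound 3, `C[S+]([O-])c1ccc(CSc2nc(-c3ccc(Br)cc3)c(-c3ccncc3)[nH]2)cc1`, 820 nM

Compound 1 stands lowest of the three numbers in this assay. The nearest is compound 3, whose number is higher by a margin beyond the scatter, and the furthest is compound 2, whose number is higher by a wider margin, also beyond the scatter. No two of the measured compounds differ in only one place, so no single step can be read off; the three differ both in the halogen on one aryl ring and in the sulfur-bearing substituent on the other.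

Compound 4, `C[S+]([O-])c1ccc(O)c(CSc2nc(-c3ccc(F)cc3)c(-c3ccncc3)[nH]2)c1`, is not yet measured. It keeps the halogen of compound 1 and rearranges the other arm: a group of 10 heavy atoms (7 carbon, 2 oxygen, 1 sulfur; one six-membered aromatic ring of carbon only) in place of a group of 10 heavy atoms (7 carbon, 2 oxygen, 1 sulfur; one six-membered aromatic ring of carbon only), on a saturated chain carbon bound to a sulfur. The group that leaves is 4-(methylsulfonyl)phenyl; the group that enters has the same atoms joined differently and has a hydrogen-bond donor where the outgoing group has none.

Compound 3 carries a sulfoxide rather than a sulfone and gives 820 nM, a higher number than compound 1, though the halogen also differs. On that basis the step from compound 1 to compound 4 is expected to be a modest rise in number, a 2.0-fold higher number from compound 1 to compound 4 (0.29 log units; within the scatter), likely beyond the scatter but not large. For compound 4 in this assay the estimate is 650 nM, with a range from 220 nM to 2000 nM.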

Compound 4, half-maximal inhibitory concentration: 1000 nM
Estimate against measurement, compound 4: 1.5-fold (0.19 log units) below, and the stated range covers the measured number.
By their numbers in this assay, from the lowest: compound 1; then compounds 3 and 4 (each within the scatter of the next); then compound 2.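

Among the compounds shown here, this is the first step with the halogen held constant, and it shows that the number in this assay responds to the arrangement of this arm alone: a 3.0-fold higher number from compound 1 to compound 4 (0.48 log units; beyond the scatter), a modest change made with no change in the heavy-atom count on the saturated chain carbon bound to a sulfur. The step bundles two changes, since 4-(methylsulfonyl)phenyl gives way to a group carrying a sulfoxide and a hydroxyl, with a hydrogen-bond donor where the outgoing group has none, so this single step cannot assign the rise to either feature. Nothing measured on these compounds bears on the origin of the step.

Open, as far as these compounds go, is how much of the step belongs to the sulfoxide and how much to the hydroxyl, a split that would need compounds with the halogen of compound 1 and only one of the two features. Also open, from the compounds shown here alone, is whether a methoxy group or an amine in place of the hydroxyl would keep, raise or lower the number in this assay.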